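A few compounds are considered here, and "the series" means these few. Any claim that something is new, unique, unknown or untested is made for them only; others in the source may bear on it.

Series notes. Compound 1 `CNC(=O)c1cc(C(=O)Nc2cnn(C)c2)cc2c1OC[C@H]2c1ccccc1`, compound 2 `CNC(=O)c1cc(C(=O)NC)c2c(c1)[C@](C)(c1ccccc1)CO2` and compound 3 `CNC(=O)c1cc(C(=O)N[C@H]2[C@@H]3COC[C@@H]32)cc2c1OC[C@@]2(CO)c1ccccc1` have been measured; compound 4 `CNC(=O)c1cc(C(=O)N[C@H]2[C@@H]3C[C@@H](O)C[C@@H]32)cc2c1OC[C@@]2(C)c1ccccc1` has not. In a physicochemical assay for solubility (on this read-out lower numbers stand for lower solubility and higher numbers for higher solubility), compound 1 gives >= 189 ug/mL, which is a limit of the assay and not a number. In this assay compound 2 gives >= 132 ug/mL, likewise a limit. In this assay compound 3 gives >= 202 ug/mL, again a limit. Compound 2 therefore stands at a limit, and the two other values shown are limits too, so no order among the three can be read. Compound 4 differs from compound 2 by a group of 7 heavy atoms (6 carbon, 1 oxygen; one three-membered non-aromatic ring of carbon only, one five-membered non-aromatic ring of carbon only) in place of one carbon atom, on an amide-type nitrogen. Among the measured compounds shown here, no measured step between two compounds is available; the change is expected to move this assay by no more than the scatter, in no clear direction. Compound 4 is expected to give about 150 ug/mL, between 60 ug/mL and 250 ug/mL. The expected step is a step that the limit leaves unreadable from compound 2 to compound 4.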

Compound 4, solubility: >= 209 ug/mL
Compound 4: only a limit was reported; the forecaster's own chance of this, stated with the estimate: 60%; at least 1.3-fold (0.14 log units) between middle value and limit.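

Compound 2 and compound 4 both stand at limits in this assay, not at numbers, and the step between them cannot be read. The compounds shown leave open where the actual solubility of each one lies.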